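This account rests on a few compounds, and the source may have more. Where it says the series, first, only, none or still open, it means among the compounds named here.

Compound 1 `COc1ccc(CN(c2cc(OC)c(OC)c(OC)c2)S(=O)(=O)c2ccccc2)cc1`, for which only a limit is reported in a functional assay on MCF7 cells (Homo sapiens) for inhibition, read by MTT assay, with a stated time of 48 h; on this read-out lower numbers stand for stronger inhibition and higher numbers for weaker inhibition: > 50000 nM
Compound 2 `COc1cc(N(Cc2cccc(C)c2)S(=O)(=O)c2ccc(C)cc2)cc(OC)c1OC`, in this assay: 14300 nM
Compound 3 `COc1cc(N(Cc2nc3ccccc3[nH]2)S(=O)(=O)c2ccccc2)cc(OC)c1OC`, in this assay: 27300 nM

Compound 3 stands at the upper end of the two numbers shown; compound 2 is its nearest neighbour and lies within the usual scatter of it, so the two cannot be told apart. For compound 1 only a limit is known (the limit of > 50000 nM in this assay, at which 1 of the 3 values shown sits). Within the data shown here, the single step between compounds that differ in one place is an at least 1.8-fold lower number from compound 1 to compound 3 (0.26 log units; that floor lies within the scatter), and its floor lies within the scatter.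

Compound 4 `COc1cc(N(Cc2nc3ccccc3[nH]2)S(=O)(=O)c2ccc(C(C)(C)C)cc2)cc(OC)c1OC` has not yet been measured. It differs from compound 3 by tert-butyl in place of hydrogen on an aromatic carbon. Among the measured compounds shown here, no measured step bears directly on this change: compound 2 carries a methyl on the ring that bears the sulfonyl group, but also a different group on the chain carbon, so its two values show only that compound 2 and compound 3 lie within the scatter of each other. The change is therefore expected to give a step of a 1.4-fold lower number from compound 3 to compound 4 (0.14 log units; within the scatter) that stays within the scatter. Compound 4 is estimated at 20000 nM, with a range from 7000 nM to 60000 nM.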

Compound 4, half-maximal inhibitory concentration: 33600 nM
Estimate against measurement, compound 4: 1.7-fold (0.23 log units) below; the measured number falls inside the stated range.
By their numbers in this assay, from the lowest: compounds 2, 3 and 4 (each within the scatter of the next, the first and the last beyond it). At a limit, above all of these: compound 1.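

Replacing phenyl with 4-(tert-butyl)phenyl gives, in this assay, a 1.2-fold higher number from compound 3 to compound 4 (0.09 log units; within the scatter). Among these compounds, this is the first pair among the compounds that differs only at this aromatic carbon, and it shows that adding a tert-butyl group here leaves compound 3 and compound 4 indistinguishable in this read-out. Nothing available here explains this outcome.

On these data alone, with only hydrogen and tert-butyl compared directly at this position, it remains open whether a different kind of group here, such as an amine or a carboxylic acid, would move the number beyond the scatter. As far as these compounds go, it also remains open whether tert-butyl would have the same small effect with 4-methoxyphenyl or another group in place of the 1H-benzimidazol-2-yl group on the chain carbon.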